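The source may hold more compounds than are shown below. What is called first, only, known or untested is meant among the compounds shown, and "the series" means these compounds.

Measured compounds in an assay on isolated protein for displacement of a labelled ligand from melanin-concentrating hormone receptor 1 (Homo sapiens); on this read-out higher numbers stand for weaker inhibition and lower numbers for stronger inhibition:
compound 1 `CC(C)N(C)c1ccc2cc(NC(=O)CCc3ccc(C(F)(F)F)cc3)ccc2n1`: 2 nM
compound 2 `O=C(CCc1ccc(C(F)(F)F)cc1)Nc1ccc2nc(N3CC4CC3CN4)ccc2c1`: 210 nM
compound 3 `CN(c1ccc2cc(NC(=O)CCc3ccc(C(F)(F)F)cc3)ccc2n1)C1CCCCC1`: 18 nM

Compound 3 stands second highest of the three numbers; compound 1 is nearest, a 9.0-fold higher number from compound 1 to compound 3 (0.95 log units; beyond the scatter), and compound 2 furthest, a 12-fold lower number from compound 2 to compound 3 (1.07 log units; beyond the scatter). The three share one core and differ only in the amine on the aromatic carbon next to the ring nitrogen.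

Compound 4 `CC1CCCN1c1ccc2cc(NC(=O)CCc3ccc(C(F)(F)F)cc3)ccc2n1` keeps that core; the change is 2-methylpyrrolidin-1-yl in place of cyclohexyl(methyl)amino on an aromatic carbon. Among the measured compounds shown here, two measured steps bear on it. a 9.0-fold higher number from compound 1 to compound 3 (0.95 log units; beyond the scatter) shows that, on this nitrogen, isopropyl gives a lower number than cyclohexyl, so a group with fewer heavy atoms than that of compound 3 points downward. a 110-fold higher number from compound 1 to compound 2 (2.02 log units; beyond the scatter) shows that the bicyclic amine with a second nitrogen gives a large increase, but compound 4 carries a single five-membered ring and one nitrogen, in count nearer the group of compound 1 than that of compound 2. A step toward a lower number is therefore expected, of a size between the two comparisons. The step from compound 3 to compound 4 is expected to be a 3.6-fold lower number from compound 3 to compound 4 (0.56 log units; beyond the scatter). The estimate for compound 4 in this assay is 5 nM, with a range from 1.5 nM to 20 nM.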

Compound 4, half-maximal inhibitory concentration: 5 nM
Compound 4: middle estimate and measured number agree at the digits printed; the range from low to high includes it.
By their numbers in this assay, from the lowest: compound 1; then compound 4; then compound 3; then compound 2.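

In this assay, a single five-membered ring holding the attached nitrogen keeps the number low, with 2-methylpyrrolidin-1-yl in place of cyclohexyl(methyl)amino giving (a 3.6-fold lower number from compound 3 to compound 4 (0.56 log units; beyond the scatter)) and the change from the bicyclic amine of compound 2 giving (a 42-fold lower number from compound 2 to compound 4 (1.62 log units; beyond the scatter)), so a ring through that nitrogen does not in itself bring the high number of compound 2. The open isopropyl(methyl)amino group still gives the lowest number of the four (a 2.5-fold higher number from compound 1 to compound 4 (0.40 log units; beyond the scatter)), and the numbers rise with the heavy atoms of the group from compound 1 through compound 4 to compound 3, while compound 2 goes against this pattern, with fewer heavy atoms in its group than compound 3 but the highest number. No measurement offered here accounts for these differences.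

The compounds shown leave open how much the ring methyl of compound 4 contributes, which pyrrolidin-1-yl would test, and whether the second nitrogen or the second ring sets compound 2 apart, which piperazin-1-yl would help to separate. As far as these compounds go, the amide chain and the trifluoromethyl group stay constant throughout, so their part in these numbers also remains open.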